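The source may hold more compounds than are shown below. What is called first, only, known or untested is meant among the compounds shown, and "the series" means these compounds.

Measured in a functional assay on A549 cells (Homo sapiens) for inhibition; on this read-out lower numbers stand for stronger inhibition and higher numbers for weaker inhibition:
- compound 1 `COc1ccc(/C=C\c2ccc3ccccc3c2)cc1N` gives > 20000 nM
- compound 2 `COc1c(N)cc(/C=C/c2ccc3ccccc3c2)cc1N` gives > 5000 nM

Neither value is an exact number. For compound 1, > 20000 nM is a limit of the assay. For compound 2, > 5000 nM is also a limit, and this is all that is known of where it stands. Compound 3 `COc1c(N)cc(/C=C\c2ccc3ccccc3c2)cc1N` has the same atoms and bonds as compound 2 and differs only in configuration as drawn (the two compounds have the same atoms and bonds and differ only in configuration as drawn: 1 of 1 stereo elements differ; a double bond is drawn E in compound 2 and Z in compound 3). Going by the values given here, with no measured step as a guide, a moderate gain in inhibition is expected, with wide uncertainty, and the estimated change is an at least 1.6-fold lower number from compound 2 to compound 3 (0.22 log units; that floor lies within the scatter) in size. For compound 3 the estimate is 3000 nM, with a value from 300 nM to 20000 nM expected.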

Compound 3, half-maximal inhibitory concentration: > 5000 nM
Compound 3 was reported as a limit (the forecaster's own chance of this, stated with the estimate: 40%); middle value at least 1.6-fold (0.22 log units) from the limit.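

Going by these compounds alone, compound 3 gives > 5000 nM, which is a limit and not a number, so no step from compound 1 or compound 2 to compound 3 can be read. From the compounds shown here alone, whether the double-bond configuration or the added amino group changes inhibition at all stays open.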